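Rearranging the Dimethylphenyl Group of Compound 2

This account rests on a few compounds, and the source may have more. Where it says the series, first, only, none or still open, it means among the compounds named here.

In a functional assay on PC-3 cells (Homo sapiens) for cytotoxicity (on this read-out lower numbers stand for an effect already at smaller amounts and higher numbers for an effect only at larger amounts of compound), compound 1 `COC1=C(C)C(=O)/C(=C(O)/C=C/c2ccc(C)cc2)C(=O)C1(C)C` gives 8.2 ug/mL and compound 2 `COC1=C(C)C(=O)/C(=C(O)/C=C/c2c(C)cccc2C)C(=O)C1(C)C` gives 17.1 ug/mL as its value. Compound 2 therefore holds the higher of the two numbers, so it needs the larger amount for the effect. The two differ only at a double-bonded chain carbon bound to a double-bonded chain carbon, where 2,6-dimethylphenyl stands in place of 4-methylphenyl. This is a 2.1-fold higher number from compound 1 to compound 2 (0.32 log units; beyond the scatter) and counts as a modest step.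

Compound 3 `COC1=C(C)C(=O)/C(=C(O)/C=C/c2cc(C)cc(C)c2)C(=O)C1(C)C` has not yet been measured. At that same place, 3,5-dimethylphenyl stands in place of 2,6-dimethylphenyl: 3,5-dimethylphenyl in place of 2,6-dimethylphenyl on a double-bonded chain carbon bound to a double-bonded chain carbon is the full difference. Among the compounds with values here, only the one measured step bears on this change, and compound 3 no longer carries the group that came with the higher number. Within the data shown here, no compound with 3,5-dimethylphenyl has a measured value yet, so a similarly modest move toward lower numbers is expected in this assay and nothing larger. The expected change is a 1.8-fold lower number from compound 2 to compound 3 (0.26 log units; within the scatter) in size. For compound 3 the estimated value is 9.5 ug/mL, with an expected range from 4.5 ug/mL to 19 ug/mL.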

Compound 3, concentration for half-maximal effect: 8.8 ug/mL
Compound 3: middle estimate off by 1.1-fold (0.03 log units), on the high side; measured number inside the range.
By their numbers in this assay, from the lowest: compounds 1, 3 and 2 (each within the scatter of the next, the first and the last beyond it).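

Moving the two methyl groups from 2,6-dimethylphenyl to 3,5-dimethylphenyl keeps the same atoms and the same counts, and in this assay it gives a 1.9-fold lower number from compound 2 to compound 3 (0.29 log units; within the scatter), so this rearrangement alone cannot be told apart from the differences seen between repeated measurements. Swapping 4-methylphenyl for 3,5-dimethylphenyl at this place on the chain gives a 1.1-fold higher number from compound 1 to compound 3 (0.03 log units; within the scatter), so this second methyl-bearing group cannot be separated from the first on this read-out, and these three aromatic groups span only a narrow band of values, with only the first and last compounds in the ranking lying beyond the scatter of each other. No measurement is available that would explain these numbers.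

As far as these compounds go, three compounds that all carry only methyl groups on the phenyl ring say little about how this position responds to anything else, so it remains open what an amine, a carboxylic acid or a methoxy group on that ring would do. From the compounds shown here alone, whether a longer chain in place of the methyl groups would move the number beyond the scatter also remains unknown.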